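Swapping a carbamoyl for a methylsulfanyl group

A few compounds are considered here, and "the series" means these few. Any claim that something is new, unique, unknown or untested is made for them only; others in the source may bear on it.

The measured compounds so far:
compound 1 `O=C(CN(c1nc(Cl)nc2[nH]cnc12)C1CC1)N[C@@H](CO)C(=O)OCc1ccccc1` gives 27.9%
compound 2 `O=C(CN(c1nc(Cl)nc2[nH]cnc12)C1CC1)NCC(=O)OCc1ccccc1` gives 18%
compound 3 `NC(=O)C[C@H](NC(=O)CN(c1ncnc2c1ncn2C1CCCCO1)C1CC1)C(=O)OCc1ccccc1` gives 21.7%

All three were tested in a functional assay on the whole organism (Tail, strain ICR) with Mus musculus as the target, in the tail flick test, with a stated time of 150 min, at a dose of 25 umol/kg by the oral route; on this read-out lower numbers stand for a weaker effect and higher numbers for a stronger effect at the one dose given. Compound 3 stands second highest of the three numbers, but its distance to compound 2 and to compound 1 is in each case within the usual scatter, so the three cannot be separated by this read-out.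

Compound 4 `CSCC[C@H](NC(=O)CN(c1ncnc2c1ncn2C1CCCCO1)C1CC1)C(=O)OCc1ccccc1` has not yet been measured. It differs from compound 3 in a single place: (methylsulfanyl)methyl in place of carbamoyl on a saturated chain carbon, two bonds along the chain from an amide-type nitrogen and a carbonyl carbon. Cut one bond further out, the same difference reads carbamoylmethyl to 2-(methylsulfanyl)ethyl.

For the measured compounds named here, only one measured step exists, a number 9.9 percentage points lower from compound 1 to compound 2 (within the scatter), and it concerns a different group on a different pair of compounds; it says nothing direct about a carbamoyl leaving or a (methylsulfanyl)methyl entering. What it does show is that altering a side group on this saturated chain carbon gave no change beyond the scatter. On that basis no step beyond the scatter is expected here either, and a number 0.3 percentage points higher from compound 3 to compound 4 (within the scatter) is the estimated change. Compound 4 is therefore expected to give about 22%, with a range from 8% to 38%.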

Compound 4, a percentage reported as activity, at one dose (the size of the read-out at that dose, not a potency): 17.5%
For compound 4 the middle estimate is 4.5 percentage points above the measured one, within the range that was stated.
By their numbers in this assay, from the lowest: compounds 4, 2, 3 and 1 (each within the scatter of the next, the first and the last beyond it).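

In this assay, the step from carbamoyl to (methylsulfanyl)methyl is a number 4.2 percentage points lower from compound 3 to compound 4 (within the scatter), so this read-out cannot separate the two compounds. For the compounds shown here, this is the first measured swap on a saturated chain carbon, two bonds along the chain from an amide-type nitrogen and a carbonyl carbon, and it replaces a group with one hydrogen-bond donor and a double bond by a sulfur-containing group with neither, with no step beyond the scatter at this one dose and time. Nothing shown here gives a measured reason for where either number lies.

Still open, going by these compounds, is whether a group of another kind at this place, such as an amine, a carboxylic acid or a longer chain of carbon atoms, would give a step beyond the scatter from compound 3. Also open, on these data alone, is whether the same swap from carbamoyl to (methylsulfanyl)methyl would behave in the same way on the core of compound 1, which carries a chlorine atom, or at doses other than the single one given here.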